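The compounds below may be only part of what the source reports. "The series", "measured", "known", "first", "only" and "open" are said of these compounds alone.

In a functional assay on MCF cells (Homo sapiens) for antiproliferative activity, with a stated time of 72 h (on this read-out higher numbers stand for weaker inhibition and lower numbers for stronger inhibition), compound 2, whose structure is `OC[C@H]1O[C@@H](n2cnc3c(NCc4ccc(Br)cc4)ncnc32)[C@H](O)[C@@H]1O`, gives only a limit of the assay, > 166000 nM, and no number. Compound 1, with structure `OC[C@H]1O[C@@H](n2cnc3c(NCc4cccc(Br)c4)ncnc32)[C@H](O)[C@@H]1O`, likewise gives only a limit, > 166000 nM. For the measured compounds named here, compound 3, with structure `OC[C@H]1O[C@@H](n2cnc3c(NCc4ccc(Cl)cc4Cl)ncnc32)[C@H](O)[C@@H]1O`, is the single compound with an actual number, 127000 nM. The step of an at least 1.3-fold lower number from compound 1 to compound 3 (0.11 log units; that floor lies within the scatter) and the step of an at least 1.3-fold lower number from compound 2 to compound 3 (0.11 log units; that floor lies within the scatter) both stay within the scatter, and the step that the two limits leave unreadable from compound 1 to compound 2 cannot be read, because the limit of > 166000 nM in this assay, at which 2 of the 3 values shown sit, is all that either of those two values reveals. So across the three measured compounds, swapping one halogen-bearing phenyl for another has not produced a readable change in potency.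

Compound 4, with structure `OC[C@H]1O[C@@H](n2cnc3c(NCc4ccc(F)c(F)c4F)ncnc32)[C@H](O)[C@@H]1O`, differs from compound 2 in a single place: 2,3,4-trifluorophenyl in place of 4-bromophenyl on a saturated chain carbon bound to a nitrogen on an aromatic ring. All three measured steps are exchanges of this kind, and none of them moves beyond the scatter. The expectation for compound 4 is therefore no step beyond the scatter, with a good chance that only a limit is reported again. Compound 4 is estimated at 160000 nM in this assay, with a range from 80000 nM to 330000 nM. That estimate corresponds to an expected step of an at least 1.0-fold lower number from compound 2 to compound 4 (0.01 log units; that floor lies within the scatter), that is, essentially no change.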

Compound 4, half-maximal inhibitory concentration: > 166000 nM
Compound 4 gave a limit, no number (the forecaster's own chance of this, stated with the estimate: 60%); middle value at least 1.0-fold (0.01 log units) from the limit.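

In this assay, the 2,3,4-trifluorophenyl group, which carries only fluorine, behaves no differently in any readable way from the bromine- and chlorine-bearing phenyl groups at this place, on a saturated chain carbon bound to a nitrogen on an aromatic ring. For the compounds shown here, the only step with a size is an at least 1.3-fold higher number from compound 3 to compound 4 (0.11 log units; that floor lies within the scatter), so the data do not separate these two compounds, although this figure is only a floor and the real gap could be larger. The steps from compound 1 and compound 2 to compound 4 cannot be read, because one limit is all that these values reveal: the limit of > 166000 nM in this assay, at which 3 of the 4 values shown sit.

All four compounds shown carry a halogen-bearing phenyl, so it remains open whether an amine or a carboxylic acid on that phenyl, or a longer chain carrying it, would bring a number well clear of this limit. It is also unknown how far compounds 1, 2 and 4 lie from one another, as none of the three has an actual number in this assay.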